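The source may report more compounds than this note shows. Statements on the series, on what has been measured and on what is new or still open speak of the compounds shown alone.

Three hydroxamic acids built on a shared core have been tested in a functional assay on PC-3 cells (Homo sapiens) for antiproliferative activity; a higher number here means a weaker inhibitor of growth, a lower number a stronger inhibitor of growth. Compound 1 `O=C(CCC1=CCN(Cc2ccc(C(F)(F)F)cc2)C1=O)NO` gives 4360 nM. Compound 2 `COc1cccc(CN2CC=C(CCC(=O)NO)C2=O)c1` gives 3890 nM, and compound 3 `COc1cccc(CCCN2CC=C(CCC(=O)NO)C2=O)c1` gives 2590 nM. Compound 2 sits between the other two in number, yet all three values lie within the usual scatter of one another, so no ordering among them can be read from these figures.

Compound 4 `O=C(CCC1=CCN(Cc2ccccc2)C1=O)NO` differs from compound 2 in one place: hydrogen in place of methoxy on an aromatic carbon. For the measured compounds named here, no measured pair shows this exact change, so the size of the step is an open question. With nothing in the three values pointing in either direction, the expected step from compound 2 to compound 4 is a 1.2-fold higher number from compound 2 to compound 4 (0.06 log units; within the scatter), which lies within the scatter. Compound 4 is therefore estimated at 4500 nM, with a likely range from 2000 nM to 10000 nM in this assay.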

Compound 4, concentration for 50% growth inhibition: 4430 nM
The estimate for compound 4 lay 1.0-fold (0.01 log units) above the measured number; the range from low to high includes it.
By their numbers in this assay, from the lowest: compounds 3, 2, 1 and 4 (each within the scatter of the next).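

In this assay hydrogen in place of methoxy on an aromatic carbon gives a 1.1-fold higher number from compound 2 to compound 4 (0.06 log units; within the scatter) and hydrogen in place of trifluoromethyl gives a 1.0-fold higher number from compound 1 to compound 4 (0.01 log units; within the scatter) in the second direct comparison. Compound 4, with neither group on its aromatic ring, therefore cannot be told apart from compound 1 or compound 2, so neither group shows a readable effect on growth inhibition in these comparisons. No supporting measurement is available to explain this result. As far as these compounds go, whether an amine or a carboxylic acid on this ring would move the number beyond the scatter remains open.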